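This account rests on a few compounds, and the source may have more. Where it says the series, first, only, none or still open, it means among the compounds named here.

Measured so far in a functional assay on HT-29 cells (Homo sapiens) for inhibition, read by MTT assay (on this read-out higher numbers stand for weaker inhibition and lower numbers for stronger inhibition), for this series
- compound 1 `COc1ccc(/C=C2\c3cc(OC)c(OC)c(OC)c3CC[C@@H]2O)cc1C#N` gives 5 nM in this series
- compound 2 `COc1ccc(/C=C2\c3cc(OC)c(OC)c(OC)c3CC[C@@H]2O)cc1N` gives 160 nM in this series
- compound 3 `COc1ccc(/C=C2\c3cc(OC)c(OC)c(OC)c3CC[C@@H]2O)cc1[N+](=O)[O-]` gives 1590 nM in this series

Compound 2 takes the middle place of the three on this assay and is separated from both neighbours beyond the scatter, by a 32-fold higher number from compound 1 to compound 2 (1.51 log units; beyond the scatter) on one side and a 9.9-fold higher number from compound 2 to compound 3 (1.00 log units; beyond the scatter) on the other.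

Compound 4 `COc1ccc(/C=C2\c3cc(OC)c(OC)c(OC)c3CC[C@H]2O)cc1N` is still to be measured. It has the same atoms and bonds as compound 2 and differs only in configuration as drawn, with the two compounds have the same atoms and bonds and differ only in configuration as drawn: 1 of 2 stereo elements differ; a stereocentre at a saturated ring carbon is drawn S in compound 2 and R in compound 4 as the whole difference: a stereocentre at a saturated ring carbon is drawn S in compound 2 and R in compound 4.

Among the measured compounds shown here, none of the measured steps changes a stereocentre. Each one swaps a group on an aromatic carbon, and they are large for a 32-fold higher number from compound 1 to compound 2 (1.51 log units; beyond the scatter) and a 320-fold higher number from compound 1 to compound 3 (2.50 log units; beyond the scatter) and modest for a 9.9-fold higher number from compound 2 to compound 3 (1.00 log units; beyond the scatter) in size. They show that a single change can move this read-out widely, but they give neither the size nor the direction of the step to compound 4.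

The expectation therefore stays anchored on compound 2 at 160 nM with a wide margin on both sides. As far as these compounds go, the expected step is a 1.6-fold higher number from compound 2 to compound 4 (0.19 log units; within the scatter) as a central guess, and a larger move in either direction remains open. For compound 4 the estimated value is 250 nM in a range from 50 nM to 1500 nM as expected limits of the likely result.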

Compound 4, half-maximal inhibitory concentration: 910 nM
Compound 4: middle estimate off by 3.6-fold (0.56 log units), on the low side; the measured number falls inside the stated range.
By their numbers in this assay, from the lowest: compound 1; then compound 2; then compounds 4 and 3 (each within the scatter of the next).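

In this assay, redrawing the stereocentre at a saturated ring carbon from S to R gives a 5.7-fold higher number from compound 2 to compound 4 (0.75 log units; beyond the scatter), so the read-out in this series responds to configuration at this carbon as well as to the group on the aromatic carbon. The step can be assigned to configuration alone, with nothing entering or leaving, because of the following: the fact that compounds 2 and 4 differ only in the configuration as drawn. Among the compounds shown here, the earlier steps all kept this stereocentre fixed and could not show this sensitivity, and the S form is the one with the lower number in this single pair, which carries the amino group on the aromatic carbon.

As far as these compounds go, whether the same change of configuration gives a step of similar size and direction with the cyano group of compound 1 or the nitro group of compound 3 remains open. Also open, from the compounds shown here alone, is how a carboxylic acid or a trifluoromethyl group in place of the amino group on the aromatic carbon would read under either configuration at the saturated ring carbon.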